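Hydroxyethyl amide of compound 2 cut back to carboxy

The source may report more compounds than this note shows. Statements on the series, on what has been measured and on what is new or still open speak of the compounds shown alone.

Measured so far in a functional assay (strain AB) with Danio rerio as the target, read by microscopy, with a stated time of 1 h; on this read-out higher numbers stand for an effect only at larger amounts of compound and lower numbers for an effect already at smaller amounts:
compound 1, `CCN1CCc2c(sc(NC(=O)Nc3ccc(Cl)cc3)c2C(=O)c2nnco2)C1`: > 25000 nM
compound 2, `CCN1CCc2c(sc(NC(=O)Nc3ccc(Cl)cc3)c2C(=O)NCCO)C1`: 9400 nM
compound 3, `CCN1CCc2c(sc(NC(=O)Nc3ccccc3)c2C(N)=O)C1`: > 25000 nM

Going by the values given here, compound 2 is the only member of the series with an actual number: in this assay compound 2 gives 9400 nM. For compound 1 the value > 25000 nM is a limit of this assay, not a number. For compound 3 the value > 25000 nM is likewise a limit. So the series sits largely at the limit of > 25000 nM in this assay, at which 2 of the 3 values shown sit, and compound 2 stands alone below it.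

Among the compounds with values here, the single measured step, an at least 2.6-fold lower number from compound 1 to compound 2 (0.42 log units; beyond the scatter), concerns the group on the carbonyl carbon and is at least modest in size; it cannot be read more precisely since compound 1 is only a limit.

Compound 4, `CCN1CCc2c(sc(NC(=O)Nc3ccc(Cl)cc3)c2C(=O)O)C1`, is to be measured in this assay. It differs from compound 2 in one place: hydroxy in place of (2-hydroxyethyl)amino on a carbonyl carbon. Within the data shown here, this change is on the same carbonyl carbon as the measured step, but no measured pair covers the loss of the (2-hydroxyethyl)amino chain, so the direction is not fixed by the data. Compound 2 already lies near the limit, so any rise in the number would push compound 4 onto it.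

For compound 4 in this assay the expected value is 20000 nM, with a range of 6000 nM to 60000 nM. The step expected is a 2.1-fold higher number from compound 2 to compound 4 (0.33 log units; beyond the scatter), a modest rise that may end as a limit rather than a number.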

Compound 4, half-maximal effective concentration: > 25000 nM
Compound 4: a limit, no number (the forecaster's own chance of this, stated with the estimate: 55%); at least 1.2-fold (0.09 log units) between middle value and limit.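

In this assay, going by these compounds alone, replacing the (2-hydroxyethyl)amino group on this carbonyl carbon with hydroxy gives an at least 2.6-fold higher number from compound 2 to compound 4 (0.42 log units; beyond the scatter), the first measured step that starts from the one compound with a number and removes its chain. Compound 4 gives > 25000 nM, which is a limit of the assay and not a number. With the chain gone, the carbonyl carbon carrying hydroxy falls in with the carbonyl carbon carrying 1,3,4-oxadiazol-2-yl, so the (2-hydroxyethyl)amino group remains the only group at this place shown with a measured value, and the series stays largely at one end of the scale: the limit of > 25000 nM in this assay, at which 3 of the 4 values shown sit.

The step between compound 1 and compound 4 cannot be read, since both values are limits, so hydroxy and 1,3,4-oxadiazol-2-yl cannot be ranked against each other at this place. The compounds shown also do not tell whether the amide nitrogen or the terminal hydroxy of the chain goes with the measured value, a question that a 2-methoxyethyl amide, a 2-aminoethyl amide or a longer hydroxyalkyl amide on the same carbonyl carbon would bear on.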